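The source may report more compounds than this note shows. Statements on the series, on what has been measured and on what is new or still open speak of the compounds shown alone.

Series notes. The shared core appears in compound 1 `NCCCCCOc1ccc([C@H]2CC[C@]3(CC2)OOC2(O3)C3CC4CC(C3)CC2C4)cc1` and compound 2 `O=S(=O)(c1ccc([C@H]2CC[C@]3(CC2)OOC2(O3)C3CC4CC(C3)CC2C4)cc1)N1CCNCC1`, which differ only in the group carried on the aromatic carbon. In an ADME assay on microsomes from liver (Homo sapiens) for metabolic stability, read by LC-MS, tested at 1 uM (on this read-out higher numbers stand for fast clearance and lower numbers for slow clearance), compound 1 gives < 7 mL.min-1.g-1, which is a limit of the assay and not a number. In this assay compound 2 gives 16 mL.min-1.g-1. Within the data shown here, the one measured step is an at least 2.2-fold higher number from compound 1 to compound 2 (0.35 log units; beyond the scatter); it involves the limit of < 7 mL.min-1.g-1 in this assay, at which 1 of the 2 values shown sits, and shows only that the number can rise away from where compound 1 stands.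

Compound 3 `c1cc([C@H]2CC[C@]3(CC2)OOC2(O3)C3CC4CC(C3)CC2C4)ccc1OCC1CCNCC1` has not yet been measured. It differs from compound 1 as follows: piperidin-4-yl in place of 4-aminobutyl on a saturated chain carbon bound to an oxygen on an aromatic ring. Among the measured compounds shown here, no measured step covers this change; the step from compound 1 to compound 2 replaces a different group and does not speak to a ring closed within the chain. The step is therefore expected to be small, an at least 1.1-fold higher number from compound 1 to compound 3 (0.05 log units; that floor lies within the scatter), with the number staying close to the limit. The estimate for compound 3 in this assay is 8 mL.min-1.g-1, in the range 4 mL.min-1.g-1 to 18 mL.min-1.g-1.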

Compound 3, intrinsic clearance in microsomes: < 7 mL.min-1.g-1
Compound 3 gave a limit, no number (the forecaster's own chance of this, stated with the estimate: 45%); at least 1.1-fold (0.05 log units) between middle value and limit.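

In this assay compound 3 sits at a limit of the assay and compound 1 sits at the same limit, so the size of the change from 4-aminobutyl to piperidin-4-yl cannot be read: the limit of < 7 mL.min-1.g-1 in this assay, at which 2 of the 3 values shown sit. What is new is that an amine held in a six-membered ring on this saturated chain carbon also reads at that limit, so the open chain of compound 1 is not the only form that does. Replacing (piperazin-1-yl)sulfonyl with (piperidin-4-yl)methoxy on the aromatic carbon gives an at least 2.2-fold lower number from compound 2 to compound 3 (0.35 log units; beyond the scatter), a second step that ends at the limit.

Going by these compounds, that step changes the link to the aromatic carbon and the amine ring together, so the share of each stays open. A (piperazin-1-yl)methoxy group or a shorter aminoalkoxy chain would begin to separate them.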